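The source may report more compounds than this note shows. Statements on the series, on what has been measured and on what is new or still open speak of the compounds shown alone.

Series in a functional assay on A549 cells (Homo sapiens), read by MTT assay, with a stated time of 72 h; a higher number here means a weaker inhibitor, a lower number a stronger inhibitor:
- compound 1 `O=c1[nH]cnc2c1c(-c1cc3ccccc3o1)cn2[C@@H]1O[C@H](CO)[C@@H](O)[C@H]1O` gives > 20000 nM, a limit.
- compound 2 `Nc1nc2c(c(-c3ccco3)cn2[C@@H]2O[C@H](CO)[C@@H](O)[C@H]2O)c(=O)[nH]1` gives > 20000 nM, a limit.
- compound 3 `Nc1nc2c(c(-c3ccsc3)cn2[C@@H]2O[C@H](CO)[C@@H](O)[C@H]2O)c(=O)[nH]1` gives > 20000 nM, a limit.

Compound 3 has no number, only a limit, and it shares that position with the other two compounds: the limit of > 20000 nM in this assay, at which 3 of the 3 values shown sit. The next compound is compound 4 `Nc1nc2c(c(-c3cc4ccccc4o3)cn2[C@@H]2O[C@H](CO)[C@@H](O)[C@H]2O)c(=O)[nH]1`, still unmeasured. The structural change is 1-benzofuran-2-yl in place of thiophen-3-yl on an aromatic carbon.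

Within the data shown here, the one measured step that bears on it is a step that the two limits leave unreadable from compound 2 to compound 3, with thiophen-3-yl in place of furan-2-yl on an aromatic carbon. That step offers no size to carry over to the new group. Compound 1 also bears the 1-benzofuran-2-yl group, and compound 1 gives > 20000 nM, again a limit. Among the measured compounds shown here, nothing measured so far therefore points to a gain in this assay, and no step beyond the scatter is expected, in either direction. The estimated step is a step that the limit leaves unreadable from compound 3 to compound 4, and it is expected to be unreadable if compound 4 also ends at a limit, which is the likely outcome. For compound 4 the estimated value is 25000 nM, with an expected range from 12000 nM to 50000 nM.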

Compound 4, half-maximal inhibitory concentration: > 100000 nM
Compound 4: no number, only a limit; the forecaster's own chance of this, stated with the estimate: 85%; at least 4.0-fold (0.60 log units) between middle value and limit.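

In this assay compound 4 gives > 100000 nM, which is a limit. Among these compounds, no step from compound 1, compound 2 or compound 3 to compound 4 can be read, as all four compounds end at limits. The compounds shown leave open how these four rank against each other and whether any group on the shared core gives a measurable value in this assay.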